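Shifting the hydroxy group on a weakly cytotoxic compound

The source may hold more compounds than are shown below. What is called first, only, known or untested is meant among the compounds shown, and "the series" means these compounds.

A pair of close relatives has been tested in a functional assay on SMMC-7721 cells (Homo sapiens) for cytotoxicity, read by MTT assay, with a stated time of 72 h; a higher number here means a weaker inhibitor, a lower number a stronger inhibitor. Compound 1 `CN(C)c1ccc(C=C2C(=O)N(c3ccc(Cl)cc3)N(c3ccc(Cl)cc3)C2=O)cc1` gives > 128000 nM, which is a limit of the assay and not a number. For the measured compounds named here, compound 2 `COc1cc(C=C2C(=O)N(c3ccc(Cl)cc3)N(c3ccc(Cl)cc3)C2=O)ccc1O` gives 64900 nM, the only true number so far, so it has no measured neighbour to be ranked against exactly. Going by the values given here, the single measured step, an at least 1.9-fold lower number from compound 1 to compound 2 (0.29 log units; that floor lies within the scatter), brought in 4-hydroxy-3-methoxyphenyl in place of 4-(dimethylamino)phenyl, and its floor lies within the scatter.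

Compound 3 `COc1cccc(C=C2C(=O)N(c3ccc(Cl)cc3)N(c3ccc(Cl)cc3)C2=O)c1O` comes next, with 2-hydroxy-3-methoxyphenyl in place of 4-hydroxy-3-methoxyphenyl on a double-bonded chain carbon bound to a double-bonded ring carbon. Among the compounds with values here, the two have the same atoms, joined differently, and no measured step tests this kind of swap. Within the data shown here, the only guide, an at least 1.9-fold lower number from compound 1 to compound 2 (0.29 log units; that floor lies within the scatter), is a different change of no clear size. The expected step is a 1.1-fold lower number from compound 2 to compound 3 (0.03 log units; within the scatter), which means no shift beyond the scatter. For compound 3 the estimate is 60000 nM, with an expected range from 20000 nM to 128000 nM.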

Compound 3, half-maximal inhibitory concentration: 64900 nM
For compound 3 the middle estimate is 1.1-fold (0.03 log units) below the measured one; the measured number falls inside the stated range.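

Moving the hydroxy group gives no change at the digits printed from compound 2 to compound 3 (within the scatter), so in this assay 2-hydroxy-3-methoxyphenyl and 4-hydroxy-3-methoxyphenyl cannot be told apart on a double-bonded chain carbon bound to a double-bonded ring carbon. Putting the new group in place of 4-(dimethylamino)phenyl gives an at least 1.9-fold lower number from compound 1 to compound 3 (0.29 log units; that floor lies within the scatter), which reads the same as the earlier step to compound 2. The value of compound 1 is a limit of the assay and not a number, so neither step from it has a true size, only a floor: the limit of > 128000 nM in this assay, at which 1 of the 3 values shown sits.

The compounds shown leave open whether a carboxylic acid or a nitro group in place of the hydroxy group would move the number beyond the scatter. They also leave open whether the methoxy group plays any part, since it is present in both compound 2 and compound 3.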